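This account rests on a few compounds, and the source may have more. Where it says the series, first, only, none or still open, it means among the compounds named here.

The measured compounds:
compound 1, `CC1(C)COc2ccccc2C1O`, 8%;
compound 2, `CC1(C)COc2ccccc2C1N`, 3.7%;
compound 3, `C#CCNC1c2cc(C)ccc2OCC1(C)C`, -6.8%.

All three were tested in an assay on BTI cells for inhibition of Amine oxidase [flavin-containing] B (Homo sapiens), read by fluorescence, with a stated time of 20 min, tested at 1 uM; a lower number here means less inhibition, a higher number more inhibition at the concentration tested (going by the name of the read-out). Compound 3 stands lowest of the three: compound 2 gives 3.7% and compound 1 gives 8%, each beyond the scatter above compound 3. Going by the values given here, the only measured step, a number 4.3 percentage points lower from compound 1 to compound 2 (within the scatter), concerns a saturated ring carbon and lies within the scatter. Compound 4, `C#CCNC1c2ccccc2OCC1(C)C`, differs from compound 3 by hydrogen in place of methyl on an aromatic carbon. Among the compounds with values here, no measured step touches the aromatic ring, so that one step bears on the present change only indirectly, by showing that a small substitution elsewhere on the shared core left the read-out essentially where it was. On that basis a step of no more than the scatter is expected, a number 6.8 percentage points higher from compound 3 to compound 4 (within the scatter), in no particular direction. Compound 4 is therefore estimated at 0%, with a range from -12% to 12%.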

Compound 4, a percentage reported as inhibition, at one concentration (the size of the read-out at that concentration, not a potency): 11.6%
For compound 4 the middle estimate is 11.6 percentage points below the measured one, within the range that was stated.
By their numbers in this assay, from the lowest: compound 3; then compounds 2, 1 and 4 (each within the scatter of the next).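

In this assay, hydrogen in place of methyl on an aromatic carbon gives a number 18.4 percentage points higher from compound 3 to compound 4 (beyond the scatter) and is the first step shown at this position, so even a single methyl here can shift the read-out. Without that methyl, the other groups show no separation: the propargyl in place of hydrogen on an amine nitrogen gives a number 7.9 percentage points higher from compound 2 to compound 4 (within the scatter) and the propargylamino in place of hydroxy gives a number 3.6 percentage points higher from compound 1 to compound 4 (within the scatter) as the two remaining steps. Nothing available explains the shift seen on removing the methyl.

From the compounds shown here alone, whether an ethyl, a methoxy or a chlorine on this aromatic carbon would behave like the methyl remains open. So does whether the methyl would shift the read-out in the same way on the compounds carrying the hydroxy or the unsubstituted amine.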